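Moving the fluorine on a biaryl pair

The source may report more compounds than this note shows. Statements on the series, on what has been measured and on what is new or still open speak of the compounds shown alone.

compound 1 `Brc1cn2ccnc2c(-c2ccc3ncn(C4CCCCC4)c3c2)n1` gives 10%
compound 2 `Fc1ccc(-c2cn3ccnc3c(-c3ccc4ncn(C5CCCCC5)c4c3)n2)cc1` gives 17.3%

Of the compounds shown here, two have been measured in a functional assay on SF-539 cells (Homo sapiens) for inhibition, read by sulforhodamine B assay, with a stated time of 48 h, tested at 10 uM; on this read-out lower numbers stand for less inhibition and higher numbers for more inhibition at the one concentration tested (going by the name of the read-out). For the measured compounds named here, the only step joining them, a number 7.3 percentage points higher from compound 1 to compound 2 (within the scatter), lies within the scatter, so the two numbers cannot be put in order; compound 2 stands with the nearest measured number, that of compound 1, within the scatter of its own.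

Compound 3 `Fc1ccccc1-c1cn2ccnc2c(-c2ccc3ncn(C4CCCCC4)c3c2)n1` has not yet been measured. It differs from compound 2 in one place: 2-fluorophenyl in place of 4-fluorophenyl on an aromatic carbon. Going by the values given here, no measured step speaks to this kind of change. Among the compounds with values here, the one step on record, between compound 1 and compound 2, puts 4-fluorophenyl in place of bromo rather than 2-fluorophenyl in place of 4-fluorophenyl, and it was itself within the scatter. Nothing in the data therefore points to a step beyond the scatter in this assay; the expected step is a number 2.3 percentage points lower from compound 2 to compound 3 (within the scatter). Compound 3 is estimated to give 15%, with a range from 3% to 30%.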

Compound 3, a percentage reported as inhibition, at one concentration (the size of the read-out at that concentration, not a potency): 4.51%
The estimate for compound 3 lay 10.5 percentage points above the measured number; the measured number falls inside the stated range.
By their numbers in this assay, from the lowest: compounds 3, 1 and 2 (each within the scatter of the next, the first and the last beyond it).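

In this assay, for the compounds shown here, 2-fluorophenyl in place of 4-fluorophenyl gives a number 12.8 percentage points lower from compound 2 to compound 3 (beyond the scatter), the first step on record beyond the scatter, so the substituent on this aromatic carbon of the six-membered ring with 2 nitrogen can separate two compounds even when they hold the same atoms and only the place of the fluorine on the phenyl ring differs. Going by these compounds alone, the comparison with the bromo compound is less telling: 2-fluorophenyl in place of bromo gives a number 5.5 percentage points lower from compound 1 to compound 3 (within the scatter), so, like compound 2, compound 3 cannot be put in order against compound 1, and the only ordered pair remains the two fluorophenyl isomers. Nothing on hand accounts for the gap between these isomers.

The compounds shown leave open whether the dependence on the fluorine's place holds for other substituents on the phenyl ring, such as chlorine, a methoxy group or a carboxylic acid. They also leave open what an amine such as piperidine or morpholine would give on this carbon in place of the whole aryl group, and how any of these would read at more than one concentration.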